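Replacing 3-methylphenyl with 4-cyanophenyl at the assay limit

This account rests on a few compounds, and the source may have more. Where it says the series, first, only, none or still open, it means among the compounds named here.

In a toxicity assay on THP-1 cells (Homo sapiens) for inhibition (a higher number here means that more compound is tolerated, a lower number that less compound is tolerated), compound 1 (`COc1ccc(-c2cnc(NC(=O)c3cccc(O)c3)n2C)cc1`) gives > 100000 nM as a limit of the assay. Compound 2 (`COc1ccc(-c2cnc(NC(=O)c3cccc(C)c3)n2C)cc1`) gives > 100000 nM as a limit and not a number. Compound 2 therefore stands only at the limit of > 100000 nM in this assay, at which 2 of the 2 values shown sit, and offers no number to measure from. Compound 3 (`COc1ccc(-c2cnc(NC(=O)c3ccc(C#N)cc3)n2C)cc1`) differs from compound 2 as follows: 4-cyanophenyl in place of 3-methylphenyl on a carbonyl carbon. Among the measured compounds shown here, the one measured step that bears on this change is a step that the two limits leave unreadable from compound 1 to compound 2 (methyl in place of hydroxy on an aromatic carbon), so no shift beyond the scatter is expected in this assay and another limit is the likeliest report. Any readable number would be expected to lie lower. The estimated change is an at least 1.1-fold lower number from compound 2 to compound 3 (0.04 log units; that floor lies within the scatter) and no more than scatter. For compound 3 the expected value is 90000 nM with 40000 nM and 100000 nM as the ends of the estimated range.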

Compound 3, half-maximal cytotoxic concentration: > 100000 nM
Compound 3: no number, only a limit (the forecaster's own chance of this, stated with the estimate: 75%); middle value at least 1.1-fold (0.04 log units) away from the limit.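

Compound 1, compound 2 and compound 3 all stand at a limit of this assay, so no step among them can be read: the limit of > 100000 nM in this assay, at which 3 of the 3 values shown sit.

The compounds shown leave open how far each lies from that limit, and which change on the carbonyl carbon would yield a readable number.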